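The compounds below may be only part of what the source reports. "The series", "measured", "known", "first", "only" and "open" are said of these compounds alone.

Compound 1, `Cc1ccc(NC(=O)N[C@H]2CC[C@H](Oc3ccc(F)cc3)CC2)cc1`, in a functional assay on CRL2813 cells (Homo sapiens) for cytotoxicity, read by sulforhodamine B assay, with a stated time of 5 days (on this read-out lower numbers stand for stronger inhibition and higher numbers for weaker inhibition), gives > 20000 nM, which is a limit of the assay and not a number.
Compound 2, `COc1ccc(NC(=O)N[C@H]2CC[C@H](Oc3ccc(F)cc3)CC2)cc1`, in this assay gives > 20000 nM, again a limit rather than a number.
Compound 3, `O=C(Nc1ccccc1Br)N[C@H]1CC[C@H](Oc2ccc(F)cc2)CC1`, in this assay gives 7700 nM.

Going by the values given here, compound 3 therefore stands as the only measured number among the three; the other two sit at the limit of > 20000 nM in this assay, at which 2 of the 3 values shown sit. Compound 4, `CSc1ccccc1NC(=O)N[C@H]1CC[C@H](Oc2ccc(F)cc2)CC1`, differs from compound 3 in a single place: methylsulfanyl in place of bromo on an aromatic carbon. Among the compounds with values here, no measured pair swaps these two groups against each other, so the nearest guidance comes from the steps that put the 2-bromophenyl in place: an at least 2.5-fold lower number from compound 1 to compound 3 (0.41 log units; beyond the scatter) and an at least 2.5-fold lower number from compound 2 to compound 3 (0.41 log units; beyond the scatter). Both show that moving from a 4-methylphenyl or 4-methoxyphenyl to the 2-bromophenyl brought the number down out of the unreadable region, though the true size of each step is hidden by the limit. Since compound 4 keeps a group on the same aromatic carbon, the expectation is a step of about a 1.0-fold higher number from compound 3 to compound 4 (0.02 log units; within the scatter) in this assay, that is, no change beyond the scatter. Compound 4 is thus estimated at 8000 nM, with a range from 2500 nM to 20000 nM.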

Compound 4, half-maximal inhibitory concentration: > 20000 nM
Compound 4: a limit, no number (the forecaster's own chance of this, stated with the estimate: 25%); middle value at least 2.5-fold (0.39 log units) from the limit.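

In this assay, methylsulfanyl in place of bromo, on an aromatic carbon ortho to a large group, gives an at least 2.5-fold higher number from compound 3 to compound 4 (0.41 log units; beyond the scatter). Compound 4 gives > 20000 nM, which is a limit of the assay and not a number. The earlier compounds showed only that a 2-bromophenyl could give a readable value, whereas this pair shows that a different group on the same aromatic carbon does not keep it, leaving compound 3 alone with a number: the limit of > 20000 nM in this assay, at which 3 of the 4 values shown sit.

The steps from compound 1 and from compound 2 to compound 4 cannot be read, with limits at both ends. Still open, on these data alone, is whether a chloro, a nitrile or an amine on this same aromatic carbon would give a readable value like bromo or a limit like methylsulfanyl.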